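The compounds below may be only part of what the source reports. "The series", "measured", "known", "first", "only" and "open" are said of these compounds alone.

Measured in an in vitro ADME assay on microsomes from liver (Mus musculus) for pharmacokinetics, read by LC-MS, with a stated time of 10 min, tested at 1 uM; on this read-out higher numbers stand for fast clearance and lower numbers for slow clearance:
compound 1 `CN1C[C@H](C(=O)Nc2cccc(F)c2)[C@@H](c2ccc(/C=C/C(=O)Nc3ccccc3N)cc2)C1` — 56 mL/min/kg
compound 2 `COc1cccc(NC(=O)[C@H]2CN(C)C[C@@H]2c2ccc(/C=C/C(=O)Nc3ccccc3N)cc2)c1` — 65 mL/min/kg
compound 3 `Cc1cc(NC(=O)[C@H]2CN(C)C[C@@H]2c2ccc(/C=C/C(=O)Nc3ccccc3N)cc2)ccc1Cl` — 65 mL/min/kg

Compound 2 sits level with compound 3 at the digits given, and the two together hold the highest numbers of the three; compound 1 is the furthest from compound 2, yet a 1.2-fold higher number from compound 1 to compound 2 (0.06 log units; within the scatter), so all three lie within the scatter of one another. The other steps, a 1.2-fold higher number from compound 1 to compound 3 (0.06 log units; within the scatter) and no change at the digits printed from compound 2 to compound 3 (within the scatter), tell the same: exchanging one substituted phenyl for another on the amide-type nitrogen has not moved the read-out.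

Compound 4 `CC(C)NC(=O)[C@H]1CN(C)C[C@@H]1c1ccc(/C=C/C(=O)Nc2ccccc2N)cc1` is not yet measured. It differs from compound 2 by isopropyl in place of 3-methoxyphenyl on an amide-type nitrogen. Going by the values given here, no measured step covers this kind of change: every step so far keeps a six-membered aromatic ring on that nitrogen and only alters what sits on it, whereas here the ring leaves and isopropyl enters. The three steps therefore bear on compound 4 only indirectly, by showing that the read-out in this assay has been insensitive to what occupies the amide-type nitrogen across compound 1, compound 2 and compound 3. The expectation is that compound 4 stays near the measured cluster, with a 1.2-fold lower number from compound 2 to compound 4 (0.07 log units; within the scatter) expected to fall within the scatter. Among the compounds with values here, the range is set wide; the change itself has no measured precedent here. Compound 4 is estimated at 55 mL/min/kg, between 30 mL/min/kg and 95 mL/min/kg.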

Compound 4, clearance: 12 mL/min/kg
For compound 4 the middle estimate is 4.6-fold (0.66 log units) above the measured one; measured number outside the range, below it.
By their numbers in this assay, from the lowest: compound 4; then compounds 1, 2 and 3 (each within the scatter of the next).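

Working notes on the amide-type nitrogen: in this assay, this position looked silent while a substituted phenyl stayed on it, but it responds once the aromatic ring leaves. Isopropyl in place of 3-methoxyphenyl gives a 5.4-fold lower number from compound 2 to compound 4 (0.73 log units; beyond the scatter), in place of 4-chloro-3-methylphenyl it gives a 5.4-fold lower number from compound 3 to compound 4 (0.73 log units; beyond the scatter), and in place of 3-fluorophenyl it gives a 4.7-fold lower number from compound 1 to compound 4 (0.67 log units; beyond the scatter), so the read-out separates compound 4 from all three phenyl compounds, each step lying beyond the scatter. Nothing available explains this separation.

The compounds shown leave open whether the lower number goes with the loss of the aromatic ring or with the isopropyl group itself, as the change removes the ring and the substituents on it in one step. Cyclohexyl on the same nitrogen would keep a six-membered ring without the aromatic one, while ethyl or a longer chain such as n-butyl would show how the read-out follows the alkyl group.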